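The source may hold more compounds than are shown below. What is called first, only, known or untested is meant among the compounds shown, and "the series" means these compounds.

For the measured compounds named here, in a functional assay on CCRF-CEM cells (Homo sapiens) for cytotoxicity, read by MTT assay, with a stated time of 72 h (on this read-out lower numbers stand for stronger inhibition of growth and higher numbers for weaker inhibition of growth), compound 3 `C[Se]c1nc(NCc2ccccc2)c2ccccc2n1` gives 61600 nM, the only actual number among the three values measured so far. Compound 1 `Sc1nc(NCc2ccccc2)c2ccccc2n1` gives > 100000 nM, which is a limit of the assay rather than a number. Compound 2 `[SeH]c1nc(NCc2ccccc2)c2ccccc2n1` gives > 100000 nM, likewise a limit. The step that the two limits leave unreadable from compound 1 to compound 2 swaps sulfur for selenium without a methyl on either. The step of an at least 1.6-fold lower number from compound 1 to compound 3 (0.21 log units; that floor lies within the scatter) and the step of an at least 1.6-fold lower number from compound 2 to compound 3 (0.21 log units; that floor lies within the scatter) both end at compound 3, and each has a floor that lies within the scatter.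

Compound 4 `CSc1nc(NCc2ccccc2)c2ccccc2n1` differs from compound 3 in one place: a group of 2 heavy atoms (1 carbon, 1 sulfur; no ring) in place of a group of 2 heavy atoms (1 carbon, 1 selenium; no ring), on an aromatic carbon. Going by the values given here, the one earlier swap of sulfur for selenium, from compound 1 to compound 2, is unreadable due to the limit of > 100000 nM in this assay, at which 2 of the 3 values shown sit, so the measured steps give no readable size for this change. Compound 4 is therefore expected to give about 75000 nM, within 30000 nM to 200000 nM. That estimate means a step of a 1.2-fold higher number from compound 3 to compound 4 (0.09 log units; within the scatter), expected to stay within the scatter.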

Compound 4, concentration for total growth inhibition: > 100000 nM
Compound 4: only a limit was reported; the forecaster's own chance of this, stated with the estimate: 35%; middle value at least 1.3-fold (0.12 log units) from the limit.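

For the compounds shown here, compound 4 gives the first readable comparison of selenium and sulfur at this position, on the aromatic carbon between two ring nitrogen atoms, with the methyl kept in place: in this assay, the change gives an at least 1.6-fold higher number from compound 3 to compound 4 (0.21 log units; that floor lies within the scatter). That size is only a floor and lies within the scatter, so these compounds do not establish a real gap between the methyl-bearing selenium group and methylsulfanyl. The steps from compound 2 to compound 4 and from compound 1 to compound 4 cannot be read, because both ends of each are limits rather than numbers: the limit of > 100000 nM in this assay, at which 3 of the 4 values shown sit.

On these data alone, whether adding the methyl changes anything on sulfur therefore stays open, as does the true size of the selenium-to-sulfur step. The compounds shown also leave open what a longer chain such as ethyl, or an amine, would do on this carbon.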